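Hydroxyethyl added to the benzamide ring: cytotoxicity outlook

The source may hold more compounds than are shown below. What is called first, only, known or untested is meant among the compounds shown, and "the series" means these compounds.

In an ADME assay on PC-3 cells (Homo sapiens) for cytotoxicity, read by CCK-8 assay, with a stated time of 6 days (on this read-out higher numbers stand for weaker inhibition and lower numbers for stronger inhibition), compound 2 `C[C@@H](Cn1ccc(-c2ccc(C#N)c(Cl)c2)n1)NC(=O)c1ccccc1` gives > 30000 nM, which is a limit of the assay rather than a number. In this assay compound 1 `CC(=O)c1cc(C(=O)N[C@H](C)Cn2ccc(-c3cc(F)c(C#N)c(Cl)c3)n2)n[nH]1` gives "not determined" (no result reported). Compound 3 `CC(O)c1cccc(C(=O)N[C@@H](C)Cn2ccc(-c3ccc(C#N)c(Cl)c3)n2)c1` carries 1-hydroxyethyl in place of hydrogen on an aromatic carbon. Among the compounds with values here, no measured step joins the two compounds, so the size of this change cannot be read from the series. The expected step of a number no higher from compound 2 to compound 3 (the limit leaves the size open) is estimated as none beyond the scatter, because compound 2 already sits at the limit of > 30000 nM in this assay, at which 1 of the 2 values shown sits. Compound 3 is therefore expected near 30000 nM, within 10000 nM to 100000 nM, with a further limit the most probable outcome.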

Compound 3, half-maximal inhibitory concentration: > 30000 nM
Compound 3 ended at the assay's limit; the forecaster's own chance of this, stated with the estimate: 75%; the middle value sits exactly at the limit.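

Compound 2 and compound 3 both stand as limits of the assay in this assay, and no step can be read between them, the two sharing one reading: the limit of > 30000 nM in this assay, at which 2 of the 3 values shown sit.

The compounds shown leave open whether any member of the series gives a measurable cytotoxicity value.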